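Changing the Aryl Group on the Ring Nitrogen of Compound 2

The compounds below may be only part of what the source reports. "The series", "measured", "known", "first", "only" and "open" are said of these compounds alone.

Measured so far:
compound 1, `COc1ccccc1N1C(=O)CSC1c1cc(F)cc(C(=O)O)c1`: 0%
compound 2, `COc1cccc(OC)c1N1C(=O)CSC1c1cccc(C(=O)NCCCCc2ccccc2)c1`: 31%
compound 3, `CCOc1ccccc1N1C(=O)C(C)SC1c1cccc(C(=O)NCCCCc2ccccc2)c1`: 53%

In a functional assay on 143B cells (Homo sapiens) for inhibition, read by CCK-8 assay, with a stated time of 72 h, tested at 1 uM (on this read-out higher numbers stand for more inhibition at the one concentration tested (going by the name of the read-out) and lower numbers for less inhibition), compound 1 gives 0%, compound 2 gives 31%, and compound 3 gives 53%. Compound 2 thus stands second highest of the three numbers. Its nearest neighbour is compound 3, whose number lies higher by a gap beyond the scatter, and the furthest is compound 1, whose number lies lower by a gap also beyond the scatter. No two of the measured compounds differ in a single place, so no measured step can be read off directly.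

The next compound is compound 4, `COc1c(F)cccc1N1C(=O)CSC1c1cccc(C(=O)NCCCCc2ccccc2)c1`, which has not yet been measured in this assay. It differs from compound 2 in one place:

3-fluoro-2-methoxyphenyl in place of 2,6-dimethoxyphenyl on an amide-type nitrogen in a ring

Because compound 3, which also carries a different aryl group on that nitrogen, gives 53%, and compound 2 gives 31%, the account expects the step from compound 2 to compound 4 in this assay to be small, within the scatter, with no strong lean either way. Compound 4 is estimated at 35%, within a range from 10% to 60%. The expected step is a number 4 percentage points higher from compound 2 to compound 4 (within the scatter), a small change at most.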

Compound 4, a percentage reported as inhibition, at one concentration (the size of the read-out at that concentration, not a potency): 5%
Beside the measured number, compound 4's estimate is 30 percentage points above it; the measured number lies below the stated range.
By their numbers in this assay, from the lowest: compounds 1 and 4 (each within the scatter of the next); then compound 2; then compound 3.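

In this assay, among these compounds, putting 3-fluoro-2-methoxyphenyl in place of 2,6-dimethoxyphenyl on the amide-type nitrogen gives a number 26 percentage points lower from compound 2 to compound 4 (beyond the scatter) and is the first change that can be read on its own. With the rest of compound 2 held fixed, the exchange of this one aryl group moves the read-out beyond the scatter, so this position is not indifferent to which aryl group it carries, at least for this pair. Nothing measured here bears on why the number falls.

The exchange removes one methoxy group and brings in a fluorine in a single step, so the compounds shown do not separate what each of these contributes to the drop. Also open, on these data alone, is how the read-out would respond on the same core to other aryl substituents at this position, such as a chlorine atom in place of the fluorine or an amine on the ring.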